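Series notes: removing the amino group from compound 1

The compounds below may be only part of what the source reports. "The series", "measured", "known", "first", "only" and "open" are said of these compounds alone.

Compound 1 `Nc1nc(Cl)c2ncn(Cc3ccccc3CCl)c2n1` carries a chloro group and an amino group on the shared core, with a chloromethyl-bearing benzyl group attached. In a functional assay on RXF 393 cells (Homo sapiens) for cytotoxicity, read by sulforhodamine B assay, with a stated time of 48 h (on this read-out lower numbers stand for higher toxicity in this test and higher numbers for lower toxicity in this test), compound 1 gives "not determined" (no result reported), so it stands on none of the numbers shown; the measured values in this set come from its relatives. Compound 2 `Nc1nc(Cl)c2ncn(Cc3ccc(CCl)cc3)c2n1` is a related benzyl analogue, and in this assay compound 2 gives 35500 nM. Compound 3 `ClCc1ccccc1Cn1cnc2ncnc(Cl)c21` has no amino group. In this assay compound 3 reaches only a limit, > 100000 nM. That value is the limit of > 100000 nM in this assay, at which 1 of the 3 values shown sits.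

Compound 4 `ClCc1ccccc1Cn1cnc2c(Cl)ncnc21` is the compound still to be measured; the change from compound 1 is hydrogen in place of amino on an aromatic carbon. Going by the values given here, no measured pair differs in the same way, so the size of the step cannot be read from data. The expectation leans on compound 3 reaching a limit, > 100000 nM: a step toward lower toxicity, beyond the usual scatter, is expected rather than none. Compound 4 is estimated at 70000 nM, with a range from 20000 nM to 250000 nM.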

Compound 4, concentration lethal to 50% of the cells: 7410 nM
Beside the measured number, compound 4's estimate is 9.4-fold (0.98 log units) above it; measured number outside the range, below it.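

No new step can be read: compound 1 has no reported number to set against compound 4. Going by these compounds, what the amino group on the shared core means for toxicity in this assay stays open. Nothing shown accounts for the value of compound 4.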